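Cytotoxicity of a Nitrile Analogue in a Sulfonamide Series

The source may hold more compounds than are shown below. What is called first, only, known or untested is meant among the compounds shown, and "the series" means these compounds.

Compound 1, `C=CCN(c1ccccc1C)S(=O)(=O)c1cc(Cl)ccc1Cl`, gives in an ADME assay on A549 cells (Homo sapiens) for cytotoxicity, read by MTT assay (a higher number here means that more compound is tolerated, a lower number that less compound is tolerated), only the assay limit > 5000 nM. Compound 2, `Cc1ccccc1N(C(C)C)S(=O)(=O)c1cc(Cl)ccc1Cl`, gives in this assay only the limit > 5000 nM. Compound 3, `CCN(c1ccccc1)S(=O)(=O)c1cc(Cl)ccc1Cl`, gives in this assay only the limit > 5000 nM.

Compound 3 therefore stands where every measured compound of this set stands: at the limit of this assay, without a numerical value of its own, and the two further values shown are limits as well. Within the data shown here, the only single-point step among the measured compounds, a step that the two limits leave unreadable from compound 1 to compound 2, isopropyl in place of allyl on a sulfonamide nitrogen, runs between two limits and its size cannot be read. Among the measured compounds shown here, all three values sit at the limit (the limit of > 5000 nM in this assay, at which 3 of the 3 values shown sit), so no step of readable size exists on which an expectation could be built.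

Compound 4, `CCN(c1ccccc1C#N)S(=O)(=O)c1cc(Cl)ccc1Cl`, differs from compound 3 by cyano in place of hydrogen on an aromatic carbon, ortho to a large group. For the measured compounds named here, no measured step bears on this change. Nothing in the measured compounds suggests that compound 4 should fall below the limit, so its value in this assay is expected to remain at or beyond it, the expected step that the limit leaves unreadable from compound 3 to compound 4 being none beyond the scatter. Compound 4 is estimated at 8000 nM, within 3000 nM to 30000 nM.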

Compound 4, half-maximal cytotoxic concentration: > 5000 nM
Compound 4: only a limit was reported; the forecaster's own chance of this, stated with the estimate: 85%; the middle value is on the limit's open side.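

In this assay compound 4 gives only the limit > 5000 nM. Among these compounds, compound 3 also stands at a limit, so no step from compound 3 to compound 4 can be read: the limit of > 5000 nM in this assay, at which 4 of the 4 values shown sit. The compounds shown leave open whether cyano in place of hydrogen on an aromatic carbon changes cytotoxicity at all, and at what concentration any of them becomes cytotoxic.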